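Acetyl to carbamoyl on the carbonyl carbon: outlook for compound 3

This account rests on a few compounds, and the source may have more. Where it says the series, first, only, none or still open, it means among the compounds named here.

Measured so far:
compound 1 `CCCOC(=O)C1=C(C)NC(=O)NC1c1ccoc1` — 50%
compound 2 `CC(=O)C1=C(C)NC(=O)NC1c1ccoc1` — 6%

In an assay on membranes from CHO cells for displacement of a labelled ligand from adenosine receptor A1 (Homo sapiens), read by scintillation counting, with a stated time of 60 min, tested at 1 uM (a higher number here means more inhibition at the concentration tested (going by the name of the read-out), a lower number less inhibition), compound 1 gives 50%, while compound 2 gives 6%. Going by the values given here, compound 2 thus stands lowest of the two numbers; its only neighbour is compound 1, and the step of a number 44 percentage points lower from compound 1 to compound 2 (beyond the scatter) is the single measured change.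

Compound 3 `CC1=C(C(N)=O)C(c2ccoc2)NC(=O)N1` differs from compound 2 in one place: amino in place of methyl on a carbonyl carbon. Among the compounds with values here, the same carbonyl carbon is the site of the one measured step, so that step is the only comparison that bears on the move to compound 3, but it covers methyl in place of propoxy and not amino in place of methyl. Its size shows that a change at this position can shift the read-out strongly. Within the data shown here, no measured pair shows what amino does here. Compound 2 already sits near the bottom of the range, so a further large fall is not possible; the expected step of a number 9 percentage points higher from compound 2 to compound 3 (within the scatter) is a small rise that may stay within the scatter. For compound 3 the estimate is 15%, with a range from 0% to 40%.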

Compound 3, a percentage reported as inhibition, at one concentration (the size of the read-out at that concentration, not a potency): 1%
Beside the measured number, compound 3's estimate is 14 percentage points above it; the range from low to high includes it.
By their numbers in this assay, from the lowest: compounds 3 and 2 (each within the scatter of the next); then compound 1.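

In this assay amino and methyl on the carbonyl carbon cannot be told apart: the step of a number 5 percentage points lower from compound 2 to compound 3 (within the scatter) shows that carbamoyl and acetyl read at the same level, so the low number is not peculiar to acetyl. Amino in place of propoxy gives a second large step, a number 49 percentage points lower from compound 1 to compound 3 (beyond the scatter) and, together with the first, this leaves the propoxy group of compound 1 as the only one of the three groups tested at this carbonyl carbon that gives a clear read-out at the concentration tested. No evidence at hand gives a reason for these numbers.

The compounds shown leave open whether the read-out of compound 1 depends on the ester oxygen or on the length of the chain: methoxy, ethoxy or butoxy on the same carbonyl carbon, or a propyl ketone, would separate the two. Also open, going by these compounds, is whether a carboxylic acid or a methylamino group at this place would stay at the level of compound 2 and compound 3 or come closer to compound 1.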